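Phenyl for nitro on a chalcone boronic acid core

The source may report more compounds than this note shows. Statements on the series, on what has been measured and on what is new or still open speak of the compounds shown alone.

Compound 2 `O=C(/C=C/c1ccc2c(c1)B(O)OC2)c1ccc([N+](=O)[O-])cc1` is assessed in an ADME assay on L929 cells (Mus musculus) for cytotoxicity, read by resazurin assay, with a stated time of 72 h; on this read-out lower numbers stand for stronger inhibition and higher numbers for weaker inhibition. In this assay compound 2 gives > 10 ug/mL, which is a limit of the assay rather than a number. Compound 1 `COc1cc(C(=O)/C=C/c2ccc3c(c2)B(O)OC3)cc(OC)c1OC` gives > 10 ug/mL, also a limit. Compound 3 `COc1cc(C(=O)/C=C/c2ccc3c(c2)B(O)OC3)ccc1[N+](=O)[O-]` gives > 10 ug/mL, again a limit. So compound 2 stands where every measured value stands, at the limit of > 10 ug/mL in this assay, at which 3 of the 3 values shown sit. Going by the values given here, the only single-point step, a step that the two limits leave unreadable from compound 2 to compound 3, is therefore unreadable. Compound 4 `O=C(/C=C/c1ccc2c(c1)B(O)OC2)c1ccc(-c2ccccc2)cc1` differs from compound 2 by phenyl in place of nitro on an aromatic carbon. Among the compounds with values here, no measured step bears on this change, so the expectation rests on the shared limit alone. Compound 4 is estimated at 15 ug/mL, within 5 ug/mL to 50 ug/mL, which is expected to mean a step that the limit leaves unreadable from compound 2 to compound 4.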

Compound 4, half-maximal inhibitory concentration: > 10 ug/mL
Compound 4: only a limit was reported; the forecaster's own chance of this, stated with the estimate: 70%; the middle value lies beyond the limit too.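

Compound 4 gives > 10 ug/mL, which is a limit and not a number. Compound 2 is also reported only as a limit, so no step can be read between compound 2 and compound 4. The compounds shown leave open whether phenyl in place of nitro makes any difference.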